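Loss of the hydroxy sulfonamide arm in the benzoxazole series

The source may hold more compounds than are shown below. What is called first, only, known or untested is meant among the compounds shown, and "the series" means these compounds.

Compound 1 `O=S(=O)(Nc1ccc(-c2nc3cc(NS(=O)(=O)c4ccccc4O)ccc3o2)cc1)c1ccccc1O` carries two arms of the same kind, and in an assay on cells for inhibition of HSP60/HSP10 (Homo sapiens), with a stated time of 60 min (a higher number here means a weaker inhibitor, a lower number a stronger inhibitor), compound 1 gives 18000 nM. Removing one of them gives compound 2 `O=S(=O)(Nc1ccc(-c2nc3ccccc3o2)cc1)c1ccccc1O`. For compound 2 the result in this assay is only a limit of the assay, > 100000 nM, not a number. The step from compound 1 to compound 2 is therefore known only as a floor: an at least 5.5-fold higher number from compound 1 to compound 2 (0.74 log units; beyond the scatter), which follows from the limit of > 100000 nM in this assay, at which 1 of the 3 values shown sits. For the measured compounds named here, compound 3 `O=S(=O)(Nc1ccc(-c2nc3ccccc3o2)cc1)c1ccccc1C(F)(F)F` keeps the single arm but changes its ring substituent; in this assay compound 3 gives 74000 nM, so an at least 1.3-fold lower number from compound 2 to compound 3 (0.13 log units; that floor lies within the scatter).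

Compound 4 `Cc1cccc(S(=O)(=O)Nc2ccc(-c3nc4ccccc4o3)cc2)c1` is the next single-arm variant. It differs from compound 2 as follows: 3-methylphenyl in place of 2-hydroxyphenyl on a sulfonyl sulfur. Going by the values given here, the only measured step that bears on this change is the one from compound 2 to compound 3, which also replaces the hydroxy on that ring, and its size was at most within the scatter once the limit is taken into account. Compound 2 itself stands at the limit, so no exact starting number is known. The expected step is accordingly small, an at least 1.2-fold lower number from compound 2 to compound 4 (0.09 log units; that floor lies within the scatter), with a value near the limit again quite possible. Compound 4 is estimated at 80000 nM in this assay, between 30000 nM and 250000 nM.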

Compound 4, half-maximal inhibitory concentration: > 100000 nM
Compound 4: only a limit was reported; the forecaster's own chance of this, stated with the estimate: 45%; middle value at least 1.2-fold (0.09 log units) from the limit.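

In this assay compound 4 gives > 100000 nM, a limit of the assay and not a number. Compound 2 stands at the same limit, so the step from compound 2 to compound 4 cannot be read: the limit of > 100000 nM in this assay, at which 2 of the 4 values shown sit.

The compounds shown leave open how 3-methylphenyl and 2-hydroxyphenyl on a sulfonyl sulfur compare in this assay.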